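A few compounds are considered here, and "the series" means these few. Any claim that something is new, unique, unknown or untested is made for them only; others in the source may bear on it.

Compound 1 `O=C(NCc1ccc(S(=O)(=O)c2ccccc2)cc1)N1Cc2cccnc2C1` gives 60 nM in an assay on isolated protein for inhibition of Nicotinamide phosphoribosyltransferase (Homo sapiens), read by mass spectrometry, with stated times of 15 min and 30 min; a higher number here means a weaker inhibitor, a lower number a stronger inhibitor. Compound 2 `O=S(=O)(c1ccccc1)c1ccc(CNS(=O)(=O)N2Cc3ccncc3C2)cc1` is recorded in this assay only as a limit, > 2000 nM. Among the measured compounds shown here, compound 3 `O=C(NCc1ccc(S(=O)(=O)C2CCC(F)(F)CC2)cc1)N1Cc2ccncc2C1` gives 78 nM in this assay, the higher of the two numbers known, although compound 1 sits within the scatter of it, so the two cannot be told apart. Compound 4 `O=C(NCc1ccc(S(=O)(=O)N2CCC[C@@H](O)C2)cc1)N1Cc2ccncc2C1` has not yet been measured. It differs from compound 3 by 3-hydroxypiperidin-1-yl in place of 4,4-difluorocyclohexyl on a sulfonyl sulfur. For the measured compounds named here, no measured step of this kind exists among the three compounds, so the direction is uncertain. The expected change is a modest step toward a weaker inhibitor, a 1.7-fold higher number from compound 3 to compound 4 (0.22 log units; within the scatter), barely beyond the scatter. Compound 4 is therefore estimated at 130 nM, with a likely range from 40 nM to 450 nM.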

Compound 4, half-maximal inhibitory concentration: 28 nM
Estimate against measurement, compound 4: 4.6-fold (0.67 log units) above; the whole stated range lies above it.
By their numbers in this assay, from the lowest: compound 4; then compounds 1 and 3 (each within the scatter of the next). At a limit, above all of these: compound 2.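

At this sulfonyl sulfur, 3-hydroxypiperidin-1-yl in place of 4,4-difluorocyclohexyl gives a 2.8-fold lower number from compound 3 to compound 4 (0.44 log units; beyond the scatter) in this assay. The carbon-only ring is therefore not required here, and a ring with a hetero atom and a hydrogen-bond donor is accepted. Nothing in the data shown bears on the cause of this step.

From the compounds shown here alone, what remains open is which part of the change matters. Plain piperidin-1-yl, without the hydroxyl, and the mirror-image form of 3-hydroxypiperidin-1-yl would separate the roles of the hydroxyl, the ring nitrogen and the defined stereocentre.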